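The source may report more compounds than this note shows. Statements on the series, on what has been measured and on what is new or still open speak of the compounds shown alone.

Compound 1 `O=C(/C=C/c1ccc2c(c1)B(O)OC2)c1cccs1`: 14200 nM in a functional assay on HCT-116 cells (Homo sapiens) for cytotoxicity, read by MTT assay, with a stated time of 48 h; a higher number here means a weaker inhibitor, a lower number a stronger inhibitor
Compound 2 `CCc1ccc(C(=O)/C=C/c2ccc3c(c2)B(O)OC3)cc1`: 10900 nM in this assay
Compound 3 `CSc1ccc(C(=O)/C=C/c2ccc3c(c2)B(O)OC3)cc1`: 10300 nM in this assay

Compound 1 gives the highest number of the three, but its gap to compound 2 and to compound 3 lies within the scatter. Compound 4 `O=C(/C=C/c1ccc2c(c1)B(O)OC2)c1ccccc1F` differs from compound 1 by 2-fluorophenyl in place of thiophen-2-yl on a carbonyl carbon. For the measured compounds named here, no measured step tracks this exact exchange; the single step of a 1.1-fold lower number from compound 2 to compound 3 (0.02 log units; within the scatter) concerns only a group on the aryl ring and stays within the scatter. The values of compound 2 and compound 3 show that ketones bearing a phenyl-type ring land near compound 1, so no step beyond the scatter is expected in this assay. Compound 4 is therefore estimated at 11000 nM, within 5000 nM to 25000 nM, a step of a 1.3-fold lower number from compound 1 to compound 4 (0.11 log units; within the scatter).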

Compound 4, half-maximal inhibitory concentration: 4200 nM
For compound 4 the middle estimate is 2.6-fold (0.42 log units) above the measured one; measured number below the stated range.
By their numbers in this assay, from the lowest: compound 4; then compounds 3, 2 and 1 (each within the scatter of the next).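

In this assay the group on the carbonyl carbon proves able to move the number: 2-fluorophenyl in place of thiophen-2-yl gives a 3.4-fold lower number from compound 1 to compound 4 (0.53 log units; beyond the scatter) and so exceeds the scatter, which the earlier aryl-ring step did not. No measured evidence bears on this step. The compounds shown leave open how the fluorine and the six-membered ring each contribute; a plain phenyl on the carbonyl carbon would separate them. An amine on that ring also remains an open case.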